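This account rests on a few compounds, and the source may have more. Where it says the series, first, only, none or still open, it means among the compounds named here.

Compound 3 `N#Cc1c(Nc2ccccc2F)nc(SCc2cn(Cc3ccc(Cl)cc3)nn2)nc1-c1ccccc1` is one of the two weakest-reading members of the set in a functional assay on MCF7 cells (Homo sapiens) for inhibition, read by MTT assay, with a stated time of 72 h; on this read-out higher numbers stand for weaker inhibition and lower numbers for stronger inhibition. In this assay compound 3 gives > 64000 nM, which is a limit of the assay and not a number. Compound 1 `N#Cc1c(Nc2ccccc2F)nc(SCc2cn(Cc3ccccc3Cl)nn2)nc1-c1ccccc1` gives 8060 nM in this assay. Within the data shown here, the one measured step, an at least 7.9-fold higher number from compound 1 to compound 3 (0.89 log units; beyond the scatter), concerns the move of the chloro group around the benzyl ring and does not touch the change now in question. Compound 2 `Cc1ccc(Cn2cc(CSc3nc(Nc4ccccc4C)c(C#N)c(-c4ccccc4)n3)nn2)cc1` gives > 64000 nM in this assay, again a limit. Two of the three values shown sit at this limit (the limit of > 64000 nM in this assay, at which 2 of the 3 values shown sit).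

Compound 4 `Cc1ccc(Cn2cc(CSc3nc(Nc4ccccc4F)c(C#N)c(-c4ccccc4)n3)nn2)cc1` differs from compound 3 by methyl in place of chloro on an aromatic carbon. Among the measured compounds shown here, compound 2 already carries the 4-methylbenzyl group, paired with a 2-methylphenyl rather than a 2-fluorophenyl, and no step between compound 2 and compound 4 is measured. For the measured compounds named here, no measured step bears directly on the chloro-to-methyl exchange. The step from compound 3 to compound 4 is expected to be a step that the limit leaves unreadable from compound 3 to compound 4, a limit-to-limit move of no real size. Compound 4 is expected to give 80000 nM in this assay, within 30000 nM to 200000 nM, most likely reported once more as a limit.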

Compound 4, half-maximal inhibitory concentration: > 64000 nM
Compound 4: no number, only a limit; the forecaster's own chance of this, stated with the estimate: 80%; the middle value is on the limit's open side.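

Methyl in place of chloro on this aromatic carbon leaves the reading in this assay at the limit: compound 4, with its 2-fluorophenyl group kept, gives > 64000 nM, a limit and not a number. Among these compounds, the steps from compound 3 and from compound 2 to this compound cannot be read, and the 4-methylbenzyl group now stands at the limit with either 2-fluorophenyl or 2-methylphenyl, so the set reads: the limit of > 64000 nM in this assay, at which 3 of the 4 values shown sit. Compound 1 keeps the only true number, and the readable step is an at least 7.9-fold higher number from compound 1 to compound 4 (0.89 log units; beyond the scatter).

Any difference between chloro and methyl at this place stays hidden behind the limit. Going by these compounds, how an amine or a carboxylic acid on this same aromatic carbon would read remains open, as does whether any such group brings a number back into range.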